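The compounds below may be only part of what the source reports. "The series", "measured", "known", "first", "only" and "open" are said of these compounds alone.

Of the compounds shown here, two have so far been measured in a functional assay on CHO cells for agonist activity at Free fatty acid receptor 1 (Homo sapiens), read by FLIPR and calcium flux; a lower number here means that less compound is needed, a higher number that more compound is needed for the effect. Compound 1, `CCOc1cc(C)c(-c2cccc(COc3ccc(S(=O)(=O)CC(=O)O)cc3)c2)c(C)c1`, gives 63.1 nM there. Compound 2, `Cc1ccccc1-c1cccc(COc2ccc(S(=O)(=O)CC(=O)O)cc2)c1`, gives 46.8 nM in this assay, and these two values lie within the scatter of each other, so neither compound can be placed ahead of the other on these numbers. The step to compound 3, `O=C(O)CS(=O)(=O)c1ccc(OCc2cccc(-c3ccccc3Cl)c2)cc1`, changes one spot: chloro in place of methyl on an aromatic carbon, so that a 2-methylphenyl becomes a 2-chlorophenyl. Among the compounds with values here, no pair of measured compounds here differs in just this way, so there is no measured step to lean on. A swap of one small group for another of this kind is expected to move the number little in either direction. Compound 3 is therefore estimated at 50 nM, with a range of 20 nM to 130 nM. The expected step is a 1.1-fold higher number from compound 2 to compound 3 (0.03 log units; within the scatter), no more than the scatter.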

Compound 3, half-maximal effective concentration: 28.8 nM
Compound 3: middle estimate off by 1.7-fold (0.24 log units), on the high side; the range from low to high includes it.
By their numbers in this assay, from the lowest: compounds 3, 2 and 1 (each within the scatter of the next, the first and the last beyond it).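

Chloro in place of methyl, on the aromatic carbon ortho to a large group, gives a 1.6-fold lower number from compound 2 to compound 3 (0.21 log units; within the scatter) in this assay. Within the data shown here, this is the first step here between two compounds that differ in one place only, and it shows that this position can carry either group with no difference that stands clear of the scatter. Nothing available explains the values of this pair or says what the two groups do at this position.

What the compounds shown leave open is how far this tolerance extends, since only methyl and chloro have been compared directly at this spot. A plain hydrogen, a methoxy, a trifluoromethyl, a nitrile or an amine there could hold the number within the scatter or move it well beyond.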